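Amino in Place of Hydroxy: What Compound 4 Might Give

The source may report more compounds than this note shows. Statements on the series, on what has been measured and on what is new or still open speak of the compounds shown alone.

Compound 1, `Oc1ccc(/C=C/c2ccccc2O)cc1`: 21 ug/mL
Compound 2, `Oc1ccc(/C=C/c2cccc(O)c2)cc1`: 23 ug/mL
Compound 3, `Nc1ccc(/C=C/c2ccccc2O)cc1`: 23 ug/mL

These three were tested in a functional assay on MCF7 cells (Homo sapiens) for inhibition, read by MTT assay, with a stated time of 2 days; on this read-out higher numbers stand for weaker inhibition and lower numbers for stronger inhibition. Compound 1 and compound 2 share the same atoms joined differently; the difference between the two cores is not broken down here, and their two values lie within the scatter of each other. Compound 3 arises from compound 1 by amino in place of hydroxy on an aromatic carbon, a step of a 1.1-fold higher number from compound 1 to compound 3 (0.04 log units; within the scatter). Compound 4, `Nc1ccc(/C=C/c2cccc(O)c2)cc1`, has not yet been measured; it arises from compound 2 by amino in place of hydroxy on an aromatic carbon, the same change made on the core of compound 2. Because the earlier step of a 1.1-fold higher number from compound 1 to compound 3 (0.04 log units; within the scatter) stayed within the scatter, compound 4 is expected to sit close to compound 2, with an estimated step of a 1.1-fold higher number from compound 2 to compound 4 (0.04 log units; within the scatter). Compound 4 is estimated at 25 ug/mL, most likely between 14 ug/mL and 45 ug/mL.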

Compound 4, half-maximal inhibitory concentration: 24.8 ug/mL
Beside the measured number, compound 4's estimate is 1.0-fold (0.00 log units) above it; low and high end bracket the measured number.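

In this assay, amino in place of hydroxy on an aromatic carbon again gives a 1.1-fold higher number from compound 2 to compound 4 (0.03 log units; within the scatter). Set beside the earlier step, the change looks alike on the two cores: the same change on two cores in this assay, a 1.1-fold higher number (0.04 log units; within the scatter) from compound 1 to compound 3 and a 1.1-fold higher number (0.03 log units; within the scatter) from compound 2 to compound 4, 1.0-fold (0.01 log units) apart, within the scatter of two such steps. On these two cores, then, the swap makes no difference that can be told from the scatter, but two such small steps cannot show how it would behave on a third core, nor why it has so little effect here.

The compounds shown leave open what other groups would give at this same place, such as a methoxy group, a dimethylamino group or a carboxylic acid. They also leave open whether any such group would move the number beyond the scatter.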